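This account rests on a few compounds, and the source may have more. Where it says the series, first, only, none or still open, it means among the compounds named here.

Measured compounds:
- compound 1, `CCOC(=O)c1cc2ccc(OCCCn3cc(CNC(=O)CCCCC4CCSS4)nn3)cc2oc1=O`, 32.4% in a functional assay on PC-12 cells (Rattus norvegicus) for cytotoxicity, read by MTT assay, with stated times of 3 h and 2 h, tested at 5 uM; on this read-out lower numbers stand for a weaker effect and higher numbers for a stronger effect at the one concentration tested
- compound 2, `CC(=O)c1cc2ccc(OCCCCCn3cc(CNC(=O)CCCCC4CCSS4)nn3)cc2oc1=O`, 22.2% in this assay

Compound 2 holds the lowest of the two numbers. Its nearest neighbour is compound 1, whose number is higher by an amount beyond the usual scatter, so the two are told apart, and compound 2 stands at the low end of what has been measured so far. For the measured compounds named here, no pair of compounds that differ in only one place has been measured, so no single structural step has a known size.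

Compound 3, `COc1ccc(-c2cc3ccc(OCCCCCn4cc(CNC(=O)CCCCC5CCSS5)nn4)cc3oc2=O)cc1`, has not yet been measured. Its structure departs from that of compound 2 in one place: 4-methoxyphenyl in place of acetyl on an aromatic carbon. Going by the values given here, with only two measured compounds and no measured single step to lean on, the size of this change in the assay is not known.

On the numbers shown, the step from compound 2 to compound 3 is expected to be small, at most a modest rise, and quite possibly none beyond the scatter: a number 5.8 percentage points higher from compound 2 to compound 3 (within the scatter). Compound 3 is therefore estimated at 28%, with a range from 12% to 45%.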

Compound 3, a percentage reported as activity, at one concentration (the size of the read-out at that concentration, not a potency): 41%
The estimate for compound 3 lay 13 percentage points below the measured number; the range from low to high includes it.
By their numbers in this assay, from the lowest: compound 2; then compounds 1 and 3 (each within the scatter of the next).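

In this assay, for the compounds shown here, putting 4-methoxyphenyl in place of acetyl on an aromatic carbon, with the rest of the molecule unchanged, gives the first single structural step that can be read: a number 18.8 percentage points higher from compound 2 to compound 3 (beyond the scatter). This shows that the group at this position, two atoms from the ring oxygen, can shift the read-out at the one concentration tested, and in this single pair the group with 8 heavy atoms and a six-membered aromatic ring goes with the higher number, while the count of hydrogen-bond acceptors stays the same. No measurement shown accounts for this rise, so it stands as an observation without an explanation.

The compounds shown leave open whether the aromatic ring or its methoxy group carries the change, and how a plain phenyl, an amine or a carboxylic acid at this position would compare. Going by these compounds alone, compound 1 differs from compound 2 and compound 3 in more than one place, so no step to it can be read, and the effect of the chain length on its own remains unknown.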